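The compounds below may be only part of what the source reports. "The series", "measured", "known", "first", "only" and "open" are said of these compounds alone.

Compound 1 `N#Cc1ccc(-c2ccc(Cn3cccc(O)c3=O)cc2)cc1`: > 10 ug/mL
Compound 2 `Cc1ccc(-c2ccc(Cn3cccc(O)c3=O)cc2)cc1`: > 10 ug/mL

In an ADME assay on THP-1 cells (Homo sapiens) for cytotoxicity, read by resazurin assay, with a stated time of 48 h (on this read-out lower numbers stand for stronger inhibition and higher numbers for weaker inhibition), compound 2 gives > 10 ug/mL, which is a limit and not a number. In this assay compound 1 gives > 10 ug/mL, which is also a limit. Both measured compounds share one position: the limit of > 10 ug/mL in this assay, at which 2 of the 2 values shown sit. Compound 3 `CN(C)c1ccc(-c2ccc(Cn3cccc(O)c3=O)cc2)cc1` carries dimethylamino in place of methyl on an aromatic carbon, para to a large group (dimethylamino in place of methyl on an aromatic carbon). Among the measured compounds shown here, the only measured step at this place, a step that the two limits leave unreadable from compound 1 to compound 2, offers no size to carry over. No change beyond the scatter is therefore expected, and the estimated step is a step that the limit leaves unreadable from compound 2 to compound 3. For compound 3 the expected value is 15 ug/mL, with an estimated range from 5 ug/mL to 45 ug/mL.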

Compound 3, half-maximal inhibitory concentration: > 10 ug/mL
Compound 3: no number, only a limit; the forecaster's own chance of this, stated with the estimate: 75%; the middle value does not contradict the limit.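

No step can be read between compound 1, compound 2 and compound 3, as each result is a limit and not a number: the limit of > 10 ug/mL in this assay, at which 3 of the 3 values shown sit. From the compounds shown here alone, whether cyano, methyl and dimethylamino differ at all in this assay stays open.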